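A few compounds are considered here, and "the series" means these few. Any claim that something is new, unique, unknown or untested is made for them only; others in the source may bear on it.

Measured so far:
compound 1, `Cc1cc(C(=O)NCc2ccccc2)nn1Cc1cc(Cl)ccc1OCc1ccccc1` — > 3.7
compound 2, `Cc1cc(C(=O)NN2CCOCC2)nn1Cc1cc(Cl)ccc1OCC(C)C` — 3.1

In a physicochemical assay for lipophilicity, at pH 7.4 (a lower number here means a more polar compound, a higher number a more lipophilic compound), compound 1 gives > 3.7, which is a limit of the assay and not a number. What is known of where compound 1 stands is the limit of > 3.7 in this assay, at which 1 of the 2 values shown sits. In this assay, going by the values given here, compound 2 gives 3.1; no step between compound 1 and compound 2 is computed, so the two values are read only side by side.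

Compound 3, `CCOC(=O)Nc1cc(C)n(Cc2cc(Cl)ccc2OCc2ccccc2)n1`, keeps the core of compound 1 and differs in one place: (ethoxycarbonyl)amino in place of benzylcarbamoyl on an aromatic carbon. The leaving group carries one six-membered aromatic ring of carbon only; the entering group has no ring and two hydrogen-bond acceptors against one. Among the compounds with values here, no measured step sets the size of this change, and compound 1 sits at a limit, so the expected step in this assay is read downward and beyond the scatter. Compound 3 is estimated at 3.2, with a range from 2.6 to 3.8. The step of a number at least 0.50 log units lower from compound 1 to compound 3 (beyond the scatter) is expected, counted from the limit of compound 1 only.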

Compound 3, distribution coefficient: > 3.7
Compound 3: only a limit was reported; the forecaster's own chance of this, stated with the estimate: 25%; at least 0.50 log units between middle value and limit.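

In this assay compound 3 gives > 3.7 as a limit of the assay and not a number. Going by these compounds alone, compound 1 also stands at a limit, so no step between compound 1 and compound 3 can be read: the limit of > 3.7 in this assay, at which 2 of the 3 values shown sit. Still open, going by these compounds, is whether (ethoxycarbonyl)amino in place of benzylcarbamoyl moves the read-out at all, and by how much.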